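This account rests on a few compounds, and the source may have more. Where it says the series, first, only, none or still open, it means among the compounds named here.

In an assay on isolated protein for inhibition of Discoidin domain-containing receptor 2 (Homo sapiens), read by ELISA, with a stated time of 60 min (on this read-out higher numbers stand for weaker inhibition and lower numbers for stronger inhibition), two compounds have been measured. Compound 1 `Cc1ccc(C(=O)Nc2cc(CN3CCN(C)CC3)cc(C(F)(F)F)c2)cc1-c1ccc2cn[nH]c2c1` gives 4.7 nM in this assay, and compound 2 `Cc1ccc(C(=O)Nc2cccc(C(F)(F)F)c2)cc1-c1ccc2c(-c3cnn(C)c3)n[nH]c2c1` gives 4.4 nM. Compound 2 has the lowest of the two numbers, yet its nearest neighbour, compound 1, differs from it by an amount within the usual scatter, so the two values show no order between them. Compound 3 `Cc1ccc(C(=O)Nc2cccc(C(F)(F)F)c2)cc1-c1ccc2c(-c3cnn(C4CCN(C)CC4)c3)n[nH]c2c1` is not yet measured. It differs from compound 2 in one place: 1-methylpiperidin-4-yl in place of methyl on an aromatic nitrogen. For the measured compounds named here, nothing measured so far tracks this kind of change, since no step between two measured compounds is known, so any expectation rests on compound 2 alone, whose value in this assay is 4.4 nM. The account expects the step of a 1.1-fold lower number from compound 2 to compound 3 (0.04 log units; within the scatter) to stay within the scatter, with no change of direction that the data could support. Compound 3 is therefore estimated to give 4 nM in this assay, with a range from 1.3 nM to 12 nM, pending the measurement.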

Compound 3, half-maximal inhibitory concentration: 3.8 nM
Beside the measured number, compound 3's estimate is 1.1-fold (0.02 log units) above it, within the range that was stated.
By their numbers in this assay, from the lowest: compounds 3, 2 and 1 (each within the scatter of the next).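

In this assay, for the compounds shown here, the exchange of methyl for 1-methylpiperidin-4-yl on the aromatic nitrogen gives a 1.2-fold lower number from compound 2 to compound 3 (0.06 log units; within the scatter), the first step that can be read at this position. It shows that this nitrogen of the five-membered aromatic ring can carry a group of seven heavy atoms, with a six-membered non-aromatic ring and a hydrogen-bond acceptor, in place of a single carbon, while the number stays within the scatter of the methyl compound; compound 2 alone could not show this. Nothing given here accounts for this outcome at the position.

As far as these compounds go, what the same nitrogen would do with a different kind of substituent stays open: a carboxylic acid on a short chain, a morpholine ring, or simply a hydrogen in place of methyl could each give a different number in this assay. Also open, from the compounds shown here alone, is whether the methyl on the piperidine nitrogen matters, as the reading for a piperidin-4-yl group carrying a hydrogen or an acetyl there is unknown.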